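A few compounds are considered here, and "the series" means these few. Any claim that something is new, unique, unknown or untested is made for them only; others in the source may bear on it.

Measured so far:
- compound 1, `Oc1cccc(-c2cc(-c3ccsc3)cc(-c3cccc(O)c3)n2)c1`, 1510 nM
- compound 2, `Oc1cccc(-c2cc(-c3cccnc3)cc(-c3ccccc3O)n2)c1`, 6230 nM

In a functional assay on T47D cells (Homo sapiens) for cytotoxicity, read by CCK-8 assay (a lower number here means a stronger inhibitor, a higher number a weaker inhibitor), compound 2 gives the highest number of the two values known, and its nearest neighbour is compound 1, whose value lies beyond the scatter below it. Compound 3, `Oc1cccc(-c2cc(-c3cccnc3)cc(-c3cccc(O)c3)n2)c1`, has not been measured. It differs from compound 2 by 3-hydroxyphenyl in place of 2-hydroxyphenyl on an aromatic carbon, a 3-hydroxyphenyl in place of 2-hydroxyphenyl on an aromatic carbon, so that compound 3 carries two 3-hydroxyphenyl groups on the shared core, as compound 1 does, while keeping the pyridin-3-yl group of compound 2. Within the data shown here, no measured pair shows this exact change, so there is no step to lean on. Still, compound 1 with its value of 1510 nM suggests that two 3-hydroxyphenyl groups sit with a lower number than compound 2 shows. The step from compound 2 to compound 3 is therefore expected to be a drop of about a 2.8-fold lower number from compound 2 to compound 3 (0.45 log units; beyond the scatter). For compound 3 the expected value is 2200 nM, within a range of 800 nM to 6000 nM.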

Compound 3, half-maximal inhibitory concentration: > 50000 nM
Compound 3: a limit, no number (the forecaster's own chance of this, stated with the estimate: 5%); middle value at least 22-fold (1.35 log units) away from the limit.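

In this assay compound 3 gives > 50000 nM, which is a limit of the assay and not a number, so the steps to it give only a minimum size. On the carbon next to the ring nitrogen, 3-hydroxyphenyl in place of 2-hydroxyphenyl swaps two groups with the same atoms, yet it gives an at least 8.0-fold higher number from compound 2 to compound 3 (0.90 log units; beyond the scatter), so where the hydroxyl sits on this ring matters greatly when pyridin-3-yl is present. Two 3-hydroxyphenyl groups also do not secure a low value by themselves, as pyridin-3-yl in place of thiophen-3-yl gives an at least 33-fold higher number from compound 1 to compound 3 (1.51 log units; beyond the scatter).

The compounds shown leave open how 2-hydroxyphenyl behaves alongside thiophen-3-yl on the shared core. They also leave open whether a methoxy group or an amine in place of the hydroxyl would keep any activity.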